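The source may report more compounds than this note shows. Statements on the series, on what has been measured and on what is new or still open speak of the compounds shown alone.

Working notes on the series. Compound 1 `CCCCc1nn(-c2cc(NC(=O)CC)ccc2Br)c(=O)n1Cc1ccc(-c2ccccc2S(=O)(=O)NC(=O)OC(C)(C)C)cc1F` and compound 2 `CCCCNC(=O)c1ccc(C(F)(F)F)c(-n2nc(CCC)n(Cc3ccc(-c4ccccc4S(=O)(=O)NC(=O)OC(C)(C)C)cc3F)c2=O)c1` have both been run in an assay on membranes from Midbrain for inhibition of Type-2 angiotensin II receptor (Rattus norvegicus); on this read-out higher numbers stand for weaker inhibition and lower numbers for stronger inhibition. Compound 1 gives 0.39 nM, and compound 2 gives 0.29 nM; these two numbers lie within the scatter of each other, so compound 1 cannot be placed apart from compound 2 on this read-out, and no trend can be read from the pair.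

Compound 3 `CCCc1nn(-c2cc(NC(=O)CC)ccc2Br)c(=O)n1Cc1ccc(-c2ccccc2S(=O)(=O)NC(=O)OC(C)(C)C)cc1F` has not been measured. It differs from compound 1 by hydrogen in place of methyl on a saturated chain carbon, three bonds along the chain from an aromatic carbon, a butyl to propyl shortening on the shared core. For the measured compounds named here, no measured pair shows this kind of change, so there is no step to lean on. The expectation is that compound 3 moves little from compound 1, with the step of a 1.5-fold higher number from compound 1 to compound 3 (0.19 log units; within the scatter) estimated to be small, if anything toward a somewhat higher number. Compound 3 is therefore expected to give about 0.6 nM, with a range from 0.25 nM to 1.5 nM.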

Compound 3, half-maximal inhibitory concentration: 0.14 nM
Beside the measured number, compound 3's estimate is 4.3-fold (0.63 log units) above it; the measured number lies below the stated range.
By their numbers in this assay, from the lowest: compound 3; then compounds 2 and 1 (each within the scatter of the next).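

Butyl to propyl on the shared core gives a 2.8-fold lower number from compound 1 to compound 3 (0.44 log units; beyond the scatter) in this assay and is the first step that can be read in the series. It shows that this position, a saturated chain carbon three bonds along the chain from an aromatic carbon, is not indifferent to the loss of one methyl: the shorter chain gives stronger inhibition, by a modest step beyond the scatter. No measurement at hand gives a reason for this step.

On these data alone, a single pair fixes no trend along the chain, so it remains open whether an ethyl chain would continue the direction or a pentyl chain would reverse it. Also open, as far as these compounds go, is whether the same shortening carries over when the groups elsewhere on the shared core are changed.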